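From 2-methoxyphenyl to 4-bromophenyl on the shared core

The source may report more compounds than this note shows. Statements on the series, on what has been measured and on what is new or still open speak of the compounds shown alone.

compound 1 `COc1ccccc1-n1cc(C(=O)c2cc(OC)c(OC)c(OC)c2)c(-c2ccccc2)c1` gives 150 nM in a functional assay on MCF7 cells (Homo sapiens) for cytotoxicity, read by MTT assay, with a stated time of 96 h; a higher number here means a weaker inhibitor, a lower number a stronger inhibitor
compound 2 `COc1cc(C(=O)c2cn(-c3cccc([N+](=O)[O-])c3)cc2-c2ccccc2)cc(OC)c1OC` gives 550 nM in this assay
compound 3 `COc1cccc(-n2cc(C(=O)c3cc(OC)c(OC)c(OC)c3)c(-c3ccccc3)c2)c1` gives 500 nM in this assay

Compound 1 has the lowest number of the three and is the strongest inhibitor in this small set, as its steps to both others lie beyond the scatter. The open case is compound 4 `COc1cc(C(=O)c2cn(-c3ccc(Br)cc3)cc2-c2ccccc2)cc(OC)c1OC`, which keeps the core of compound 1 but swaps the group on an aromatic nitrogen: 4-bromophenyl in place of 2-methoxyphenyl on an aromatic nitrogen (4-bromophenyl in place of 2-methoxyphenyl).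

Two measured steps change this same group. Placing 3-methoxyphenyl there gives a 3.3-fold higher number from compound 1 to compound 3 (0.52 log units; beyond the scatter) and placing 3-nitrophenyl there gives a 3.7-fold higher number from compound 1 to compound 2 (0.56 log units; beyond the scatter), both modest and both upward. The two replacements barely differ from each other, with a 1.1-fold lower number from compound 2 to compound 3 (0.04 log units; within the scatter) inside the scatter. Within the data shown here, neither carries bromine, and no measured compound has 4-bromophenyl, so this guide is loose. A modest rise is still the likeliest outcome, perhaps a little smaller than those two steps. The expected change is a 2.3-fold higher number from compound 1 to compound 4 (0.37 log units; beyond the scatter) (an estimate only). Compound 4 is estimated at 350 nM, with an expected range from 100 nM to 1100 nM (a wide span).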

Compound 4, half-maximal inhibitory concentration: 20 nM
Compound 4: middle estimate off by 18-fold (1.24 log units), on the high side; the whole stated range lies above it.
By their numbers in this assay, from the lowest: compound 4; then compound 1; then compounds 3 and 2 (each within the scatter of the next).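

Among these compounds, until this result, every measured replacement of the 2-methoxyphenyl group on the aromatic nitrogen had raised the number, but 4-bromophenyl reverses that direction in this assay, with a 7.5-fold lower number from compound 1 to compound 4 (0.88 log units; beyond the scatter). Compound 4 is therefore the strongest inhibitor of the four, and this position can move the number downward as well as upward, with steps of a 25-fold lower number from compound 3 to compound 4 (1.40 log units; beyond the scatter) and a 28-fold lower number from compound 2 to compound 4 (1.44 log units; beyond the scatter) that are far larger than the small difference seen between the 3-methoxyphenyl and 3-nitrophenyl groups. No measurement is available to explain why the 4-bromophenyl group gives this lower number.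

The change from 2-methoxyphenyl to 4-bromophenyl alters both the atom on the phenyl ring and where it sits, so the compounds shown cannot separate the contribution of the bromine from that of its location. They also leave open what would happen if a chlorine atom, a fluorine atom, an amine or a carboxylic acid took the place of the bromine on the phenyl ring.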